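This account rests on a few compounds, and the source may have more. Where it says the series, first, only, none or still open, it means among the compounds named here.

Values in a functional assay on HepG2 cells (Homo sapiens) for cytotoxicity, read by MTT assay, with a stated time of 72 h; a lower number here means a stronger inhibitor, a higher number a weaker inhibitor:

Compound 1 `O=C(COc1ccc(-c2cc(=O)c3ccccc3o2)cc1)NC1CCN(Cc2ccccc2)CC1` — 15500 nM
Compound 2 `N#Cc1ccc(CN2CCC(NC(=O)COc3ccc(-c4cc(=O)c5ccccc5o4)cc3)CC2)cc1` — 6700 nM
Compound 3 `O=C(COc1ccc2c(=O)cc(-c3ccccc3)oc2c1)NC1CCN(Cc2ccccc2)CC1` — 16700 nM

Compound 4 `N#Cc1ccc(CN2CCC(NC(=O)COc3ccc4c(=O)cc(-c5ccccc5)oc4c3)CC2)cc1` remains unmeasured in this assay.

Compound 1 and compound 3 carry the same atoms joined differently; the difference between the two cores is not broken down here, and their values in this assay lie within the scatter of each other. Compound 2 differs from compound 1 by cyano in place of hydrogen on an aromatic carbon, and that change gave a 2.3-fold lower number from compound 1 to compound 2 (0.36 log units; beyond the scatter). Compound 4 differs from compound 3 by cyano in place of hydrogen on an aromatic carbon, the same change at a place described in the same words, so it is taken as the same change.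

The expected step is a 2.2-fold lower number from compound 3 to compound 4 (0.35 log units; beyond the scatter), resting on the measured step of a 2.3-fold lower number from compound 1 to compound 2 (0.36 log units; beyond the scatter). Compound 4 is therefore estimated at 7500 nM. The expected range for compound 4 runs from 3500 nM to 16000 nM.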

Compound 4, half-maximal inhibitory concentration: 9300 nM
Beside the measured number, compound 4's estimate is 1.2-fold (0.09 log units) below it; the measured number falls inside the stated range.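

In this assay, going from benzyl to 4-cyanobenzyl on the second core gives a 1.8-fold lower number from compound 3 to compound 4 (0.25 log units; within the scatter). The two cores show no detectable difference in how they respond to this change: the same change on two cores in this assay, a 2.3-fold lower number (0.36 log units; beyond the scatter) from compound 1 to compound 2 and a 1.8-fold lower number (0.25 log units; within the scatter) from compound 3 to compound 4, 1.3-fold (0.11 log units) apart, within the scatter of two such steps. Among these compounds, this supports carrying the step between these two cores in this assay, but with only two pairs it sets no rule for other cores, and the step on the second core cannot be read as a real difference on its own.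

As far as these compounds go, whether an amine, a carboxylic acid or a methoxy group in the place of cyano would behave the same way remains open. From the compounds shown here alone, the effect of a longer chain in place of benzyl also remains open.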